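Removing the chloro from compound 1: expected effect on binding

The source may report more compounds than this note shows. Statements on the series, on what has been measured and on what is new or still open speak of the compounds shown alone.

Three compounds of this series have numbers in an assay on HEK293 cells for displacement of a labelled ligand from Neuronal acetylcholine receptor; alpha4/beta2 (Homo sapiens) (a lower number here means a stronger inhibitor, a higher number a weaker inhibitor), so far. Compound 1 `Clc1cncc(N2CCCNCCC2)c1` gives 2 nM; compound 2 `COc1cncc(N2CCCNCC2)c1` gives 1.91 nM, and the gap between compound 1 and compound 2 lies within the scatter of repeated measurements, so no order between them is claimed. Compound 3 `COc1cc(N2CCNCC2)cnc1Br` gives 182 nM, a higher number than compound 1 by a margin that is beyond the scatter. Compound 1 thus sits with the lower numbers of the set, paired with compound 2 and far from compound 3.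

The next compound, compound 4 `c1cncc(N2CCCNCCC2)c1`, differs from compound 1 in one place: hydrogen in place of chloro on an aromatic carbon. The chloro leaves an aromatic carbon of a six-membered aromatic ring with 1 nitrogen, two atoms from the ring nitrogen, and hydrogen takes its place. Going by the values given here, no measured pair in the set shows this change, so its size must be guessed. The step from compound 1 to compound 4 is expected to raise the number somewhat, as a 4.0-fold higher number from compound 1 to compound 4 (0.60 log units; beyond the scatter), beyond the scatter but modest. For compound 4 the estimate in this assay is 8 nM, with a range from 2 nM to 30 nM.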

Compound 4, half-maximal inhibitory concentration: 0.891 nM
Compound 4: the middle estimate sits 9.0-fold (0.95 log units) above what was measured; measured number below the stated range.
By their numbers in this assay, from the lowest: compound 4; then compounds 2 and 1 (each within the scatter of the next); then compound 3.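

In this assay, going by these compounds alone, the first direct reading at this position gives a 2.2-fold lower number from compound 1 to compound 4 (0.35 log units; beyond the scatter), so on this core the chloro, two atoms from the ring nitrogen, is not required for a low number, and its loss brings a modest gain rather than a penalty. Within the data shown here, only one matched pair carries this change. The result describes this position on the core of compound 1 and sets no rule for the series. Nothing available bears on why the number moves in this direction.

As far as these compounds go, it remains open how a fluoro, a nitrile or a longer alkyl chain at this position would compare with the hydrogen of compound 4. Also open, from the compounds shown here alone, is whether the same replacement of chloro by hydrogen would give a step of similar size and direction on a different core.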